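The source may hold more compounds than are shown below. What is called first, only, known or untested is meant among the compounds shown, and "the series" means these compounds.

Compound 1 `Cc1cccc(/C=C2/SC(N3CCC[C@H]3C(=O)Nc3ccc4ncnc(Nc5cccc(Cl)c5)c4c3)=NC2=O)n1` gives 8500 nM
Compound 2 `O=C1N=C(N2CCC[C@H]2C(=O)Nc2ccc3ncnc(Nc4cccc(Cl)c4)c3c2)S/C1=C/c1cccnc1` gives 10400 nM
Compound 3 `O=C1N=C(N2CCC[C@H]2C(=O)Nc2ccc3ncnc(Nc4cccc(Cl)c4)c3c2)S/C1=C/c1cccs1` gives 6100 nM

These three compounds were tested in a functional assay on A549 cells (Homo sapiens) for antiproliferative activity, read by MTT assay (on this read-out higher numbers stand for weaker inhibition and lower numbers for stronger inhibition), and differ only in the group on a double-bonded chain carbon bound to a double-bonded ring carbon. Compound 3, which carries thiophen-2-yl at that place, gives 6100 nM and stands level with the other two. Its steps are a 1.4-fold lower number from compound 1 to compound 3 (0.14 log units; within the scatter) and a 1.7-fold lower number from compound 2 to compound 3 (0.23 log units; within the scatter) while the remaining step is a 1.2-fold higher number from compound 1 to compound 2 (0.09 log units; within the scatter) and so none of these exchanges has moved the read-out beyond the scatter. Three compounds are a narrow basis, however.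

Within the data shown here, compound 4 `O=C1N=C(N2CCC[C@H]2C(=O)Nc2ccc3ncnc(Nc4cccc(Cl)c4)c3c2)S/C1=C/c1cccc(Br)n1` has 6-bromopyridin-2-yl in place of thiophen-2-yl (6-bromopyridin-2-yl in place of thiophen-2-yl on a double-bonded chain carbon bound to a double-bonded ring carbon) and no measured compound carries this group. The closest measured group is the 6-methylpyridin-2-yl of compound 1, which gives 8500 nM and thus offers the best guide. With every measured step this small, no shift beyond the scatter is expected in this assay for this exchange. The expected change is a 1.3-fold higher number from compound 3 to compound 4 (0.12 log units; within the scatter) and it should not be read as a real difference. For compound 4 the estimated value is 8000 nM with 3500 nM as the expected lower end and 18000 nM as the upper end.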

Compound 4, half-maximal inhibitory concentration: 3100 nM
Estimate against measurement, compound 4: 2.6-fold (0.41 log units) above; the measured number lies below the stated range.
By their numbers in this assay, from the lowest: compounds 4, 3, 1 and 2 (each within the scatter of the next, the first and the last beyond it).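

Among these compounds, compound 4 shows that the group on a double-bonded chain carbon bound to a double-bonded ring carbon can move the read-out of this assay beyond the scatter, which no exchange among the earlier compounds had done: the change to 6-bromopyridin-2-yl gives a 3.4-fold lower number from compound 2 to compound 4 (0.53 log units; beyond the scatter) and, for bromo in place of methyl on an aromatic carbon, a 2.7-fold lower number from compound 1 to compound 4 (0.44 log units; beyond the scatter). Both steps are modest, and the remaining one, a 2.0-fold lower number from compound 3 to compound 4 (0.29 log units; within the scatter), stays within the scatter, so compound 3 and compound 4 cannot be told apart and the thiophen-2-yl group of compound 3 serves about as well here as the 6-bromopyridin-2-yl group. The step from compound 1 is the sharpest of these comparisons, since the ring stays the same and only the atom or group on that aromatic carbon changes, yet nothing available explains the shift.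

Going by these compounds, whether a chloro, a methoxy or an amine on that aromatic carbon would follow bromo or methyl remains open. Also open, on these data alone, is whether the bromo would give a similar step on the pyridin-3-yl ring of compound 2 or on the thiophen-2-yl ring of compound 3.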